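Carbamate Swap Predicts Weaker Cell Inhibition for Methoxybenzyl Analogue

The source may hold more compounds than are shown below. What is called first, only, known or untested is meant among the compounds shown, and "the series" means these compounds.

Of the compounds shown here, three have been tested in a functional assay on MGC-803 cells (Homo sapiens) for inhibition, read by MTT assay, with a stated time of 72 h; a higher number here means a weaker inhibitor, a lower number a stronger inhibitor. Compound 3 `O=C(OCc1ccccc1)N1CCN(C(=S)SCc2cn(Cc3ccc(Cl)c(Cl)c3)nn2)CC1` gives 7140 nM. Compound 1 `COc1ccc(Cn2cc(CSC(=S)N3CCN(C(=O)OCc4ccccc4)CC3)nn2)cc1` gives 23800 nM, and compound 2 `CC(C)(C)OC(=O)N1CCN(C(=S)SCc2cn(Cc3ccc(Cl)c(Cl)c3)nn2)CC1` gives 33700 nM. Two structural changes connect them. From compound 3 to compound 1 the change is 4-methoxyphenyl in place of 3,4-dichlorophenyl on a saturated chain carbon bound to an aromatic nitrogen and the step is a 3.3-fold higher number from compound 3 to compound 1 (0.52 log units; beyond the scatter). From compound 2 to compound 3 the step is a 4.7-fold lower number from compound 2 to compound 3 (0.67 log units; beyond the scatter), and the cores of compound 2 and compound 3 differ by tert-butyl in place of benzyl on an oxygen next to a carbonyl group.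

Compound 4 `COc1ccc(Cn2cc(CSC(=S)N3CCN(C(=O)OC(C)(C)C)CC3)nn2)cc1` has not yet been measured. It is made from compound 2 by 4-methoxyphenyl in place of 3,4-dichlorophenyl on a saturated chain carbon bound to an aromatic nitrogen, the same change as from compound 3 to compound 1, since the two place descriptions agree word for word. On that single measured step, compound 4 is expected to sit at an estimated 2.7-fold higher number from compound 2 to compound 4 (0.43 log units; beyond the scatter) from compound 2 in this assay. That rests on one pair only, so the expectation is loose, and compound 2 already stands at the high end of the three numbers, which raises the chance that only a limit is reported. Compound 4 is estimated at 90000 nM, with a range from 35000 nM to 230000 nM.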

Compound 4, half-maximal inhibitory concentration: 22800 nM
Compound 4: middle estimate off by 3.9-fold (0.60 log units), on the high side; the measured number lies below the stated range.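

In this assay, 4-methoxyphenyl in place of 3,4-dichlorophenyl on the core carrying tert-butyl gives a 1.5-fold lower number from compound 2 to compound 4 (0.17 log units; within the scatter), so this change does not carry over at the size seen on the core carrying benzyl: the same change on two cores in this assay, a 3.3-fold higher number (0.52 log units; beyond the scatter) from compound 3 to compound 1 and a 1.5-fold lower number (0.17 log units; within the scatter) from compound 2 to compound 4, 4.9-fold (0.69 log units) apart, beyond the scatter of two such steps

Likewise, tert-butyl in place of benzyl on the core carrying 4-methoxyphenyl gives a 1.0-fold lower number from compound 1 to compound 4 (0.02 log units; within the scatter), which does not match the step between these two groups on the core carrying 3,4-dichlorophenyl: the same change on two cores in this assay, a 4.7-fold lower number (0.67 log units; beyond the scatter) from compound 2 to compound 3 and a 1.0-fold higher number (0.02 log units; within the scatter) from compound 4 to compound 1, 4.9-fold (0.69 log units) apart, beyond the scatter of two such steps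

In these four compounds, then, the size of each step depends on the group at the other place, but the numbers do not say why, and two cores cannot show how either change would behave on a third.

Going by these compounds, it remains open whether 4-chlorophenyl or unsubstituted phenyl on a saturated chain carbon bound to an aromatic nitrogen would follow 3,4-dichlorophenyl or 4-methoxyphenyl. Also open, on these data alone, is how a small group such as methyl or ethyl in place of benzyl or tert-butyl would fit this picture.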